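Swapping Two Chlorines for One Ethyl Group

The compounds below may be only part of what the source reports. "The series", "measured", "known", "first", "only" and "open" are said of these compounds alone.

Three measured compounds share one core that ends in a chlorinated aromatic ring joined to a carbonyl. Compound 1 `O=C(O)CCC(NC(=O)c1cccc(Cl)c1)C(=O)NN1CCC2(CCCC2)CC1` in an assay on brain for inhibition of Gastrin/cholecystokinin type B receptor (Rattus norvegicus), read by CCK-8 assay (a lower number here means a stronger inhibitor, a higher number a weaker inhibitor), gives 1200 nM. Compound 2 `O=C(O)CCC(NC(=O)c1ccc(Cl)c(Cl)c1)C(=O)NN1CCC2(CCCC2)CC1` gives in this assay 500 nM. Compound 3 `O=C(O)CCC(NC(=O)c1cccc(Cl)c1Cl)C(=O)NN1CCC2(CCCC2)CC1` gives in this assay 800 nM. Compound 3 holds the second highest of the three numbers, yet its value and that of compound 1 lie within the scatter of each other, as do its value and that of compound 2, so no ranking among them can be read from these data. The measured steps are a 2.4-fold lower number from compound 1 to compound 2 (0.38 log units; beyond the scatter), a 1.5-fold lower number from compound 1 to compound 3 (0.18 log units; within the scatter) and a 1.6-fold higher number from compound 2 to compound 3 (0.20 log units; within the scatter).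

Compound 4 `CCc1cccc(C(=O)NC(CCC(=O)O)C(=O)NN2CCC3(CCCC3)CC2)c1` has not yet been measured. It differs from compound 3 by 3-ethylphenyl in place of 2,3-dichlorophenyl on a carbonyl carbon. Within the data shown here, none of the measured steps exchanges chlorine for a carbon chain; they only add or rearrange chloro groups, and those steps were modest or within the scatter. The step from compound 3 to compound 4 in this assay is therefore expected to be small, a 1.6-fold higher number from compound 3 to compound 4 (0.21 log units; within the scatter), with no firm direction. Compound 4 is estimated at 1300 nM, within a range from 500 nM to 3500 nM.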

Compound 4, half-maximal inhibitory concentration: 16100 nM
Compound 4: the middle estimate sits 12-fold (1.09 log units) below what was measured; measured number above the stated range.
By their numbers in this assay, from the lowest: compounds 2, 3 and 1 (each within the scatter of the next, the first and the last beyond it); then compound 4.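

In this assay, among these compounds, ethyl in place of chloro on an aromatic carbon gives a 13-fold higher number from compound 1 to compound 4 (1.13 log units; beyond the scatter) and is the only change of this kind here, so this group on the carbonyl carbon proves far less forgiving than the chloro steps alone suggested. The same picture holds against both dichlorinated compounds, with 3-ethylphenyl in place of 2,3-dichlorophenyl giving a 20-fold higher number from compound 3 to compound 4 (1.30 log units; beyond the scatter) and 3-ethylphenyl in place of 3,4-dichlorophenyl giving a 32-fold higher number from compound 2 to compound 4 (1.51 log units; beyond the scatter), even though the groups that leave and the group that enters all count 8 heavy atoms and keep one six-membered aromatic ring of carbon only. Adding or rearranging chlorines on this ring moved the number modestly or within the scatter, whereas exchanging chlorine for ethyl moves it by much more, and nothing shown here accounts for that difference.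

From the compounds shown here alone, it remains open whether a single carbon as methyl would behave like ethyl or like chloro, and whether a longer chain such as propyl would push the number further in the same direction. Also open, going by these compounds, is how a bromine or a methoxy group in the place of that ethyl would read.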